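Working notes: from compound 3 to compound 4

This account rests on a few compounds, and the source may have more. Where it says the series, first, only, none or still open, it means among the compounds named here.

Measured so far in a functional assay on U2OS cells (Homo sapiens) for cytotoxicity, read by MTT assay, with a stated time of 48 h; on this read-out lower numbers stand for stronger inhibition and higher numbers for weaker inhibition:
- compound 1 `Fc1cccc(-c2nc(Nc3cccc(Cl)c3)c3cc(F)ccc3n2)c1` gives > 50000 nM (a limit)
- compound 2 `Fc1cccc(-c2nc(Nc3ccc(Br)cc3)c3cc(F)ccc3n2)c1` gives > 50000 nM (a limit)
- compound 3 `Fc1cccc(-c2nc(Nc3cccc(Br)c3)c3cc(F)ccc3n2)c1` gives > 50000 nM (a limit)

Compound 3 sits with the others in the series, as the limit of > 50000 nM in this assay, at which 3 of the 3 values shown sit, shows, so it has no number of its own to start from. The next compound is compound 4 `Nc1ccc(Nc2nc(-c3cccc(F)c3)nc3ccc(F)cc23)cc1` and it has not yet been measured. The change is 4-aminophenyl in place of 3-bromophenyl on a nitrogen on an aromatic ring and it puts 4-aminophenyl in place of 3-bromophenyl on a nitrogen on an aromatic ring.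

The measured steps that bear on it are a step that the two limits leave unreadable from compound 1 to compound 2 then a step that the two limits leave unreadable from compound 1 to compound 3 then a step that the two limits leave unreadable from compound 2 to compound 3 and none of them gives a size. Going by the values given here, no measured compound carries 4-aminophenyl, so the data offer no direct precedent for this group. The expectation rests on compound 3 at > 50000 nM as a limit. Expected in this assay is an at least 1.4-fold lower number from compound 3 to compound 4 (0.15 log units; that floor lies within the scatter) toward stronger inhibition, a modest and loosely estimated move, and a further limit reading remains quite possible. For compound 4 the expected value is 35000 nM with an estimated range of 8000 nM to 60000 nM once it is measured.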

Compound 4, half-maximal inhibitory concentration: 44200 nM
Compound 4: the middle estimate sits 1.3-fold (0.10 log units) below what was measured, and the stated range covers the measured number.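

In this assay, compound 4 is the only compound shown with a number rather than a limit, so 4-aminophenyl on a nitrogen on an aromatic ring gives the series its first readable comparison, while the steps among compound 1, compound 2 and compound 3 cannot be read: the limit of > 50000 nM in this assay, at which 3 of the 4 values shown sit.

The new comparisons are an at least 1.1-fold lower number from compound 3 to compound 4 (0.05 log units; that floor lies within the scatter), an at least 1.1-fold lower number from compound 2 to compound 4 (0.05 log units; that floor lies within the scatter) and an at least 1.1-fold lower number from compound 1 to compound 4 (0.05 log units; that floor lies within the scatter). Each is only a floor within the usual scatter, so the series shows that this change brings the reading under the assay limit, but it does not establish a gain of any real size.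

The compounds shown leave open whether that reading follows the amino group in particular or would also appear with a hydroxyl, a dimethylamino group or an acetamide in its place. On these data alone, the true size of the step from the bromo and chloro compounds also stays open, and with it whether the amino group matters much in this assay at all.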